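The source may report more compounds than this note shows. Statements on the series, on what has been measured and on what is new or still open speak of the compounds shown alone.

Measured compounds:
compound 1, `CCC1=C(O)c2c(oc(-c3ccccc3OC)cc2=O)C(CC)(CC)C1=O` — 3.26 uM
compound 2, `CCC1=C(O)c2c(oc(-c3ccccc3F)cc2=O)C(CC)(CC)C1=O` — 3.93 uM
compound 3, `CCC1=C(O)c2c(oc(-c3cc(C)c(C)cc3C)cc2=O)C(CC)(CC)C1=O` — 4.37 uM

In a functional assay on KBVIN cells (Homo sapiens) for antiproliferative activity, read by sulforhodamine B assay, with a stated time of 3 days (on this read-out lower numbers stand for an effect already at smaller amounts and higher numbers for an effect only at larger amounts of compound), compound 3 gives the highest number of the three, yet the steps reaching it, a 1.3-fold higher number from compound 1 to compound 3 (0.13 log units; within the scatter) and a 1.1-fold higher number from compound 2 to compound 3 (0.05 log units; within the scatter), both stay within the scatter. Compound 4 is `CCC1=C(O)c2c(oc(-c3ccc(F)c(C)c3)cc2=O)C(CC)(CC)C1=O`; the change from compound 3 is 4-fluoro-3-methylphenyl in place of 2,4,5-trimethylphenyl on an aromatic carbon. Every measured step exchanges one aryl group for another on the same carbon of the shared core, and each was small: a 1.2-fold higher number from compound 1 to compound 2 (0.08 log units; within the scatter), a 1.3-fold higher number from compound 1 to compound 3 (0.13 log units; within the scatter), a 1.1-fold higher number from compound 2 to compound 3 (0.05 log units; within the scatter). No step beyond the scatter is therefore expected for a further aryl exchange, and compound 4 is expected to show a 1.2-fold lower number from compound 3 to compound 4 (0.06 log units; within the scatter). For compound 4 the estimate in this assay is 3.8 uM, within a range of 1.9 uM to 7.6 uM.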

Compound 4, concentration for half-maximal effect: 1.62 uM
Estimate against measurement, compound 4: 2.3-fold (0.37 log units) above; the whole stated range lies above it.
By their numbers in this assay, from the lowest: compounds 4, 1, 2 and 3 (each within the scatter of the next, the first and the last beyond it).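

In this assay, an aryl exchange at this position can move the number beyond the scatter: 4-fluoro-3-methylphenyl gives a 2.7-fold lower number from compound 3 to compound 4 (0.43 log units; beyond the scatter) and a 2.4-fold lower number from compound 2 to compound 4 (0.38 log units; beyond the scatter). The exception is a 2.0-fold lower number from compound 1 to compound 4 (0.30 log units; within the scatter), which stays within the scatter. No measurement on hand explains these steps. Going by these compounds, whether the fluoro or the methyl group of the entering aryl group carries the steps remains open. So does what an aryl group bearing an amine or a carboxylic acid would give on this carbon.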